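The source may report more compounds than this note shows. Statements on the series, on what has been measured and on what is new or still open speak of the compounds shown alone.

Compound 1 `CN(C(=O)c1ccccc1)c1ccc2[nH]c(-c3n[nH]c4ccccc34)cc2n1`: 4850 nM
Compound 2 `CN(C(=O)c1ccc(Br)cc1)c1ccc2[nH]c(-c3n[nH]c4ccccc34)cc2n1`: 1080 nM

Both were tested in a functional assay on HL-60 cells (Homo sapiens) for antiproliferative activity, read by MTT assay, with a stated time of 72 h; a lower number here means a stronger inhibitor, a higher number a weaker inhibitor. Within the data shown here, compound 2 stands at the lower of the two numbers; the one measured step is a 4.5-fold lower number from compound 1 to compound 2 (0.65 log units; beyond the scatter). Compound 3 `CN(C(=O)c1ccco1)c1ccc2[nH]c(-c3n[nH]c4ccccc34)cc2n1` is the next structure. It differs from compound 2 in this way: furan-2-yl in place of 4-bromophenyl on a carbonyl carbon. Among the measured compounds shown here, only that single step bears on the change, and it shows the bromo being removed again here, while nothing measured speaks to the furan-2-yl itself. A step back toward, or somewhat past, the level of compound 1 is therefore expected: a 4.2-fold higher number from compound 2 to compound 3 (0.62 log units; beyond the scatter). Compound 3 is estimated at 4500 nM, with a range from 1500 nM to 13000 nM.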

Compound 3, half-maximal inhibitory concentration: 4540 nM
Estimate against measurement, compound 3: 1.0-fold (0.00 log units) below; the range from low to high includes it.
By their numbers in this assay, from the lowest: compound 2; then compounds 3 and 1 (each within the scatter of the next).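

Exchanging the ring on the carbonyl carbon gives a 4.2-fold higher number from compound 2 to compound 3 (0.62 log units; beyond the scatter), so the furan-2-yl does not keep the gain seen with the 4-bromophenyl. Compared with the plain phenyl, it gives a 1.1-fold lower number from compound 1 to compound 3 (0.03 log units; within the scatter), so these two rings cannot be told apart here, and of the three compounds only the bromo-bearing one stands apart. Nothing measured here explains this result. Still open, on these data alone, is whether a chloro or a methoxy in place of the bromo would give a similar gain, and whether a bromo on the furan ring would do the same.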